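The compounds below may be only part of what the source reports. "The series", "measured", "known", "first", "only" and "open" are said of these compounds alone.

Measured so far in a functional assay on MDA-MB-468 cells (Homo sapiens) for cytotoxicity, read by sulforhodamine B assay, with a stated time of 48 h, tested at 1 uM; a higher number here means a weaker effect of the compound at the concentration tested, a lower number a stronger effect:
Compound 1 `Cc1cc(O)cc(-c2nn(CC#N)cc2-c2ccnc(-c3ccc(Oc4ccccc4)cc3)c2)c1`: -62%
Compound 2 `COc1cc(C)cc(-c2nn(CC#N)cc2-c2ccnc(-c3ccc(N(C)C)cc3)c2)c1`: -55%

These two numbers lie within the usual scatter of each other, so this assay does not set compound 2 apart from compound 1. Compound 3 `Cc1cc(O)cc(-c2nn(CC#N)cc2-c2ccnc(-c3ccc(N(C)C)cc3)c2)c1` has not been measured; it follows from compound 2 through one change: hydrogen in place of methyl on an oxygen on an aromatic ring. The resulting hydroxy group is already present in compound 1, which gives -62%, close to compound 2. Within the data shown here, no measured pair isolates this change, so the expected step is one within the scatter: a number 3 percentage points lower from compound 2 to compound 3 (within the scatter). For compound 3 the expected value in this assay is -58%, between -78% and -38%.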

Compound 3, a percentage reported as activity, at one concentration (the size of the read-out at that concentration, not a potency): -50%
Compound 3: middle estimate off by 8 percentage points, on the low side, and the stated range covers the measured number.
By their numbers in this assay, from the lowest: compounds 1, 2 and 3 (each within the scatter of the next, the first and the last beyond it).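

In this assay, hydrogen in place of methyl on the oxygen gives a number 5 percentage points higher from compound 2 to compound 3 (within the scatter), so methoxy and hydroxy on this ring cannot be told apart here. Dimethylamino in place of phenoxy on an aromatic carbon gives a number 12 percentage points higher from compound 1 to compound 3 (beyond the scatter), so the group at that other place shows a modest difference where this oxygen change shows none. Nothing measured here explains either step.

From the compounds shown here alone, whether a longer chain on the oxygen, such as ethoxy, would also stay within the scatter remains open. So does how a ring amine such as morpholine would compare with dimethylamino and phenoxy.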